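The source may hold more compounds than are shown below. What is called first, only, known or untested is meant among the compounds shown, and "the series" means these compounds.

Of the compounds shown here, three have been measured in an assay on Sf9 cells for inhibition of histone-lysine N-methyltransferase EZH2 (Homo sapiens), read by scintillation counting, with a stated time of 60 min, in the presence of a further agent that is not named here; on this read-out lower numbers stand for stronger inhibition and higher numbers for weaker inhibition. Compound 1 `Cc1cc(C)c(CN2CCc3c(Cl)cc(-c4cn[nH]c4)c(Cl)c3C2=O)c(=O)[nH]1` gives in this assay 51 nM, the lowest of the three numbers. Compound 3 `COc1ccc2c(c1Cl)C(=O)N(Cc1c(C)cc(C)[nH]c1=O)CCC2`, the nearest of the others, gives in this assay 150 nM, a gap beyond the usual scatter, and compound 2 `COc1cccc(C(=O)NCc2c(C)cc(C)[nH]c2=O)c1Cl`, the furthest, gives in this assay 7200 nM. Going by the values given here, no two of the measured compounds differ in only one place, so no single structural step can be read from them; what the three numbers show is only that compound 1 sits well apart from both compound 2 and compound 3.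

Compound 4 `Cc1cc(C)c(CN2CCc3c(Cl)cc(-c4cn[nH]c4C)c(Cl)c3C2=O)c(=O)[nH]1` has not yet been measured. It differs from compound 1 in one place: methyl in place of hydrogen on an aromatic carbon. That is, on the five-membered aromatic ring with two nitrogens, on the aromatic carbon next to the ring nitrogen and next to the ring atom that bears a large group, a methyl takes the place of a hydrogen, so that 1H-pyrazol-4-yl becomes 5-methyl-1H-pyrazol-4-yl.

Nothing in the measured set speaks to this particular change, and a single methyl added at an aromatic carbon is a small addition. He therefore expects compound 4 to stay close to compound 1, with a step of a 1.2-fold higher number from compound 1 to compound 4 (0.07 log units; within the scatter) that is not expected to go beyond the scatter in either direction. His estimate for compound 4 in this assay is 60 nM, with a range from 20 nM to 200 nM.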

Compound 4, half-maximal inhibitory concentration in the histone-lysine N-methyltransferase EZH2 assay: 24 nM
Estimate against measurement, compound 4: 2.5-fold (0.40 log units) above, within the range that was stated.
By their numbers in the histone-lysine N-methyltransferase EZH2 assay, from the lowest: compound 4; then compound 1; then compound 3; then compound 2.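

Going by these compounds alone, the change from 1H-pyrazol-4-yl to 5-methyl-1H-pyrazol-4-yl gives the first single-place comparison in this set. In the histone-lysine N-methyltransferase EZH2 assay compound 1 gives 51 nM and compound 4 gives 24 nM. In the histone-lysine N-methyltransferase EZH2 assay the change is a 2.1-fold lower number from compound 1 to compound 4 (0.33 log units; beyond the scatter), a modest step that shows this aromatic carbon can carry a methyl without any loss of inhibition. In a physicochemical assay for lipophilicity, at pH 7.4 (a lower number here means a more polar compound, a higher number a more lipophilic compound), compound 1 gives 3 and compound 4 gives 3.1. In the physicochemical assay the same change gives a number 0.10 log units higher from compound 1 to compound 4 (within the scatter), so the two compounds cannot be told apart on distribution coefficient, and the modest gain in inhibition comes with no measurable shift in that read-out. Nothing among the data offers an explanation for the gain in inhibition.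

With only hydrogen and methyl shown at this carbon, it remains open whether an ethyl, a methoxy, a chlorine or an amine there would extend the gain, keep it or lose it. It also remains open whether the gain belongs to this carbon alone, since a methyl on a ring nitrogen of the same ring, or the same change on another core, does not appear among these compounds.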